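The source may hold more compounds than are shown below. What is called first, only, known or untested is meant among the compounds shown, and "the series" means these compounds.

In a functional assay on HT-29 cells (Homo sapiens) for inhibition, with a stated time of 72 h (a higher number here means a weaker inhibitor, a lower number a stronger inhibitor), two compounds with the same core have been measured so far. Compound 1 `COc1ccc(S(=O)(=O)N2CCc3cccc(-c4ccco4)c32)cc1` gives 62.5 nM and compound 2 `COc1ccc(S(=O)(=O)N2CCc3cccc(-c4ccc(F)c(F)c4)c32)cc1` gives 57 nM, so compound 2 stands level with compound 1 within the scatter. Still unmeasured is compound 3 `COc1ccc(S(=O)(=O)N2CCc3cccc(-c4ccc(N(C)C)cc4)c32)cc1`, which differs from compound 2 in one place: 4-(dimethylamino)phenyl in place of 3,4-difluorophenyl on an aromatic carbon. Here 4-(dimethylamino)phenyl comes in place of 3,4-difluorophenyl on an aromatic carbon. Going by the values given here, only one measured step bears on this: a 1.1-fold lower number from compound 1 to compound 2 (0.04 log units; within the scatter), which swapped furan-2-yl for 3,4-difluorophenyl and stays within the scatter. Among the compounds with values here, that single step is thin evidence, and no measured compound carries the dimethylamino group, so the range must stay wide. No step beyond the scatter is expected in this assay, and the estimated step is a 1.1-fold higher number from compound 2 to compound 3 (0.06 log units; within the scatter). Compound 3 is estimated at 65 nM, with an expected range from 20 nM to 200 nM.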

Compound 3, half-maximal inhibitory concentration: 467 nM
For compound 3 the middle estimate is 7.2-fold (0.86 log units) below the measured one; measured number above the stated range.
By their numbers in this assay, from the lowest: compounds 2 and 1 (each within the scatter of the next); then compound 3.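

In this assay this aromatic carbon does not treat every ring alike: 4-(dimethylamino)phenyl brings an 8.2-fold higher number from compound 2 to compound 3 (0.91 log units; beyond the scatter) when it replaces 3,4-difluorophenyl and a 7.5-fold higher number from compound 1 to compound 3 (0.87 log units; beyond the scatter) when it replaces furan-2-yl at the same place. Furan-2-yl and 3,4-difluorophenyl had stood level within the scatter, so the position looked tolerant until this third group showed that the choice of group here can change the number beyond the scatter. No measurement at hand says what lies behind this loss.

Three compounds cannot show whether the loss belongs to the dimethylamino group itself or would also appear with other groups on the phenyl ring. A plain phenyl, or a phenyl carrying a methoxy group or a primary amine, would help to settle that.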